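A hydroxymethyl group added to compound 3

A few compounds are considered here, and "the series" means these few. Any claim that something is new, unique, unknown or untested is made for them only; others in the source may bear on it.

Values measured so far in a functional assay on cells (Homo sapiens) for cytotoxicity, read by sulforhodamine B assay, with a stated time of 2 days (on this read-out lower numbers stand for stronger inhibition and higher numbers for weaker inhibition), are these:
Compound 1 `CN(C)c1ccc(-c2nc3c(s2)C(O)CNC3)cc1` – 1630 nM
Compound 2 `OCc1cc(N2CCCC2)ccc1-c1nc2c(s1)C(O)CCC2` – 44 nM
Compound 3 `OC1CNCc2nc(-c3ccc(N4CCCC4)cc3)sc21` – 1070 nM

The step of a 1.5-fold lower number from compound 1 to compound 3 (0.18 log units; within the scatter) leaves compound 3 within the scatter of compound 1, while compound 2 at 44 nM stands far lower than both.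

Compound 4 `OCc1cc(N2CCCC2)ccc1-c1nc2c(s1)C(O)CNC2` differs from compound 3 hydroxymethyl in place of hydrogen on an aromatic carbon by hydroxymethyl in place of hydrogen on an aromatic carbon, ortho to a large group and meta to a pyrrolidin-1-yl group. Going by the values given here, the one measured step concerns a different place, so it gives no size for this change. Compound 2 at 44 nM carries hydroxymethyl too, but its core also differs from that of compound 3 at 1070 nM and the data cannot divide that gap between the two changes. Only part of the gap is therefore expected to appear here, an estimated 3.6-fold lower number from compound 3 to compound 4 (0.55 log units; beyond the scatter) in this assay overall. For compound 4 the estimated value is 300 nM with an expected range of 70 nM to 1300 nM in this assay as well.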

Compound 4, half-maximal inhibitory concentration: 60 nM
Beside the measured number, compound 4's estimate is 5.0-fold (0.70 log units) above it; the measured number lies below the stated range.
By their numbers in this assay, from the lowest: compounds 2 and 4 (each within the scatter of the next); then compounds 3 and 1 (each within the scatter of the next).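

In this assay, hydroxymethyl in place of hydrogen on an aromatic carbon, ortho to a large group and meta to a pyrrolidin-1-yl group, gives an 18-fold lower number from compound 3 to compound 4 (1.25 log units; beyond the scatter) on an unchanged core, so this single change alone produces a large step. With hydroxymethyl present on both, compound 2 at 44 nM and compound 4 at 60 nM lie within the scatter of each other, so these two cores are not told apart by their values. Nothing measured here explains the size of this step.

On these data alone, whether a methyl, a methoxymethyl, an aminomethyl or a carboxylic acid at this carbon would give a step of similar size remains open. Also open, as far as these compounds go, is whether hydroxymethyl gives the same step when dimethylamino stands in place of pyrrolidin-1-yl.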